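Swapping Isopropoxy for Pentyloxy: A Step Still Unmeasured

The compounds below may be only part of what the source reports. "The series", "measured", "known", "first", "only" and "open" are said of these compounds alone.

Measured in a functional assay on the whole organism (strain Sprague-Dawley) for inhibition, with Rattus norvegicus as the target, with a stated time of 10 min; on this read-out higher numbers stand for an effect only at larger amounts of compound and lower numbers for an effect already at smaller amounts:
- compound 1 `O=C(O)c1cnc(-c2ccccc2F)[nH]c1=O`: 5 mg/kg
- compound 2 `CCCOc1ccccc1-c1ncc(C(=O)O)c(=O)[nH]1`: 0.9 mg/kg
- compound 3 `CC(C)Oc1ccccc1-c1ncc(C(=O)O)c(=O)[nH]1`: 0.8 mg/kg

Compound 3, at 0.8 mg/kg, stands level with compound 2 within the scatter, as a 1.1-fold lower number from compound 2 to compound 3 (0.05 log units; within the scatter) shows. Compound 1 lies well apart, with a 6.3-fold lower number from compound 1 to compound 3 (0.80 log units; beyond the scatter) beyond the scatter. Compound 4 `CCCCCOc1ccccc1-c1ncc(C(=O)O)c(=O)[nH]1` has pentyl in place of isopropyl on an oxygen on an aromatic ring. The nearest evidence is the step between compound 2 and compound 3, which also changes the group on that oxygen and stays within the scatter. The modest steps of a 5.6-fold lower number from compound 1 to compound 2 (0.74 log units; beyond the scatter) and a 6.3-fold lower number from compound 1 to compound 3 (0.80 log units; beyond the scatter) replace fluoro, so they bear on this change only loosely. Among the measured compounds shown here, no pentyl compound has yet been measured in this assay, which leaves the direction uncertain. A small rise at most is expected, not a step beyond the scatter. The expected change is a 1.5-fold higher number from compound 3 to compound 4 (0.18 log units; within the scatter). For compound 4 the estimate is 1.2 mg/kg, with an expected range of 0.4 mg/kg to 4 mg/kg.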

Compound 4, dose for 50% inhibition: 3 mg/kg
Compound 4: middle estimate off by 2.5-fold (0.40 log units), on the low side; the range from low to high includes it.
By their numbers in this assay, from the lowest: compounds 3 and 2 (each within the scatter of the next); then compounds 4 and 1 (each within the scatter of the next).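

In this assay, the group on an oxygen on an aromatic ring now proves able to shift the dose: the earlier change from propyl to isopropyl stayed within the scatter, but pentyl moves the number beyond it, with a 3.8-fold higher number from compound 3 to compound 4 (0.57 log units; beyond the scatter) and a 3.3-fold higher number from compound 2 to compound 4 (0.52 log units; beyond the scatter). Pentyloxy also cannot be told apart from fluoro at this place, as a 1.7-fold lower number from compound 1 to compound 4 (0.22 log units; within the scatter) lies within the scatter, whereas propoxy and isopropoxy both stood clear of fluoro. No evidence at hand accounts for this shift.

The compounds shown leave open whether a butyl group on that oxygen would read with propyl or with pentyl, and so where along the chain the shift sets in. They also leave open how a shorter ethyl or methyl group, or a chain ending in an amine, would read at this place.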